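Cyclohexenyl for hexyl on the pyridine-like core of compound 1

This account rests on a few compounds, and the source may have more. Where it says the series, first, only, none or still open, it means among the compounds named here.

Compound 1, `CCCCCCc1nc(C(F)(F)F)ccc1CNC(=O)C(C)c1ccc(NS(C)(=O)=O)c(F)c1`, is one of two measured members of this series. In an assay on CHO cells for antagonist activity at transient receptor potential cation channel subfamily V member 1 (Homo sapiens), read by FLIPR and calcium flux (on this read-out higher numbers stand for weaker inhibition and lower numbers for stronger inhibition), compound 1 gives 1.6 nM. The other measured member, compound 2, `C[C@H](C(=O)NCc1ccc(C(F)(F)F)nc1C1CC2CCC1C2)c1ccc(NS(C)(=O)=O)c(F)c1`, gives 0.8 nM in this assay; the two numbers lie within the scatter of each other, so nothing separates them on present data.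

Compound 3, `CC(C(=O)NCc1ccc(C(F)(F)F)nc1C1=CCCCC1)c1ccc(NS(C)(=O)=O)c(F)c1`, is not yet measured. It differs from compound 1 in one place: cyclohex-1-en-1-yl in place of hexyl on an aromatic carbon. Within the data shown here, no measured pair shows this kind of change, so any expectation rests on the two measured numbers alone. Both carry different groups at this position of the shared core and both sit in the same narrow range, so the step from compound 1 to compound 3 is expected to stay within the scatter, a 1.3-fold lower number from compound 1 to compound 3 (0.12 log units; within the scatter), with no clear direction. Compound 3 is estimated at 1.2 nM in this assay, in the range 0.4 nM to 4 nM.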

Compound 3, inhibition constant: 0.7 nM
Estimate against measurement, compound 3: 1.7-fold (0.23 log units) above; the measured number falls inside the stated range.
By their numbers in this assay, from the lowest: compounds 3, 2 and 1 (each within the scatter of the next, the first and the last beyond it).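

Closing hexyl into cyclohex-1-en-1-yl at the same heavy-atom count gives the first readable step at this position, on an aromatic carbon next to the ring nitrogen: a 2.3-fold lower number from compound 1 to compound 3 (0.36 log units; beyond the scatter) in this assay, a modest change. The position therefore accepts a six-membered non-aromatic ring with a double bond in place of an open chain, and the number does not rise. Nothing available explains this step.

The compounds shown leave open whether the step goes with the ring or with its double bond, a question that a saturated cyclohexyl group at this place would separate. All the groups shown here are carbon only, so it also remains open how a piperidine or a morpholine would fare at this position.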